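The compounds below may be only part of what the source reports. "The series", "measured", "known", "first", "only" and "open" are said of these compounds alone.

In a functional assay on A2780 cells (Homo sapiens) for antiproliferative activity, read by resazurin assay, with a stated time of 72 h (a lower number here means a stronger inhibitor, a higher number a weaker inhibitor), three compounds sharing one core have been measured. Compound 1 `CN(Cc1cccc(Cl)c1)C(=O)c1cc2c(Cc3ccccc3)n[nH]c2cc1O` gives 5300 nM, compound 2 `CN(Cc1cccc(Br)c1)C(=O)c1cc2c(Cc3ccccc3)n[nH]c2cc1O` gives 7100 nM, and compound 3 `CN(Cc1ccc(F)cc1)C(=O)c1cc2c(Cc3ccccc3)n[nH]c2cc1O` gives 4100 nM. Compound 3 lies within the scatter of both others, so the three numbers form a single level and no order can be read among them.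

The next structure is compound 4 `COc1cc(CN(C)C(=O)c2cc3c(Cc4ccccc4)n[nH]c3cc2O)ccc1Cl`, which carries 4-chloro-3-methoxyphenyl in place of 4-fluorophenyl on a saturated chain carbon bound to an amide-type nitrogen.

Within the data shown here, three measured steps bear on this change. Bromo in place of chloro gave a 1.3-fold higher number from compound 1 to compound 2 (0.13 log units; within the scatter). 4-fluorophenyl in place of 3-chlorophenyl gave a 1.3-fold lower number from compound 1 to compound 3 (0.11 log units; within the scatter), and 4-fluorophenyl in place of 3-bromophenyl gave a 1.7-fold lower number from compound 2 to compound 3 (0.24 log units; within the scatter). All three stay within the scatter, which holds for these three compounds only. Going by these compounds, none of them carries a methoxy group, so that part of the change remains untested and the wider range below allows for it.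

No step beyond the scatter is expected in this assay, and no direction can be argued from these data. The estimated change is a 1.2-fold higher number from compound 3 to compound 4 (0.09 log units; within the scatter). For compound 4 the expected value is 5000 nM, with an estimated range of 2300 nM to 10000 nM.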

Compound 4, half-maximal inhibitory concentration: 4100 nM
Compound 4: the middle estimate sits 1.2-fold (0.09 log units) above what was measured, and the stated range covers the measured number.
By their numbers in this assay, from the lowest: compounds 3, 4, 1 and 2 (each within the scatter of the next).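

In this assay, among these compounds, a methoxy group stands on this ring for the first time, and 4-chloro-3-methoxyphenyl in place of 4-fluorophenyl gives no change at the digits printed from compound 3 to compound 4 (within the scatter) on a saturated chain carbon bound to an amide-type nitrogen. Against the two other aryl groups, the same ring gives a 1.7-fold lower number from compound 2 to compound 4 (0.24 log units; within the scatter) and a 1.3-fold lower number from compound 1 to compound 4 (0.11 log units; within the scatter), so the series stays at a single level across all four compounds, and no order can be read among them. This position therefore accepts a larger group with one hydrogen-bond acceptor, where the earlier compounds had only single halogens and no acceptor in this group, without any step beyond the scatter; no evidence is available here to explain that flat result.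

The compounds shown leave open whether a step beyond the scatter can arise at this position at all, for example with an amine, a carboxylic acid or a longer chain on the benzyl ring. They also leave open what methoxy does on this ring without the chloro group.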